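Replacing Fluoro with Chloro on the Benzyl Ring

A few compounds are considered here, and "the series" means these few. Any claim that something is new, unique, unknown or untested is made for them only; others in the source may bear on it.

Compound 1 `Cc1ccc(-c2nn(-c3ccccc3)cc2C(=O)NOCc2ccccc2Cl)cc1`: 2640 nM
Compound 2 `COc1ccc(-c2nn(-c3ccccc3)cc2C(=O)NOCc2ccccc2)cc1`: 2770 nM
Compound 3 `COc1ccc(-c2nn(-c3ccccc3)cc2C(=O)NOCc2ccccc2F)cc1`: 6000 nM

All three were tested in a functional assay on MCF7 cells (Homo sapiens) for antiproliferative activity, read by MTT assay, with a stated time of 48 h, in the presence of a further agent that is not named here; on this read-out higher numbers stand for weaker inhibition of growth and lower numbers for stronger inhibition of growth. Among the compounds with values here, compound 3 gives the highest number of the three, and the one single-point step measured, a 2.2-fold higher number from compound 2 to compound 3 (0.34 log units; beyond the scatter), shows that adding fluoro raised the number beyond the scatter.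

Compound 4 `COc1ccc(-c2nn(-c3ccccc3)cc2C(=O)NOCc2ccccc2Cl)cc1` differs from compound 3 by chloro in place of fluoro on an aromatic carbon. Within the data shown here, no measured step sets chloro directly against fluoro. The closest evidence comes from compound 1, which also carries a 2-chlorobenzyl group but methyl rather than methoxy and gives 2640 nM, while compound 2, with an unsubstituted benzyl group, gives 2770 nM; these two values are within the usual scatter of each other. Chloro therefore seems to leave the number near where hydrogen leaves it, whereas fluoro pushed it up. Compound 4 is thus expected to give a lower number than compound 3, a step of about a 2.0-fold lower number from compound 3 to compound 4 (0.30 log units; within the scatter). The estimate for compound 4 is 3000 nM, with a range from 1500 nM to 6500 nM.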

Compound 4, concentration for 50% growth inhibition: 3730 nM
For compound 4 the middle estimate is 1.2-fold (0.09 log units) below the measured one; measured number inside the range.
By their numbers in this assay, from the lowest: compounds 1, 2, 4 and 3 (each within the scatter of the next, the first and the last beyond it).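

In this assay the direct exchange of chloro in place of fluoro gives a 1.6-fold lower number from compound 3 to compound 4 (0.21 log units; within the scatter) and so the two halogens cannot be told apart at this position, even though fluoro in place of hydrogen alone gave a step beyond the scatter. Chloro in place of hydrogen gives a 1.3-fold higher number from compound 2 to compound 4 (0.13 log units; within the scatter) and methoxy in place of methyl, at the far end of the molecule, gives a 1.4-fold higher number from compound 1 to compound 4 (0.15 log units; within the scatter) and both of these also stay too small to read as real changes. Nothing measured on these groups is available that could explain these numbers.

The compounds shown leave open how bromo or an amine would read on this same aromatic carbon. They also leave open whether fluoro and chloro would stay this close with a group other than methoxy on the far ring.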